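A few compounds are considered here, and "the series" means these few. Any claim that something is new, unique, unknown or untested is made for them only; others in the source may bear on it.

Three compounds with a shared core have been examined in an assay on isolated protein for inhibition of protein phosphatase 1D (Homo sapiens), read by malachite green; a higher number here means a weaker inhibitor, a lower number a stronger inhibitor. Compound 1 `N#Cc1ccc(-c2nc(-c3ccc4[nH]c(=O)oc4c3)cs2)cc1` gives < 20000 nM, which is a limit of the assay rather than a measured number. Compound 2 `Cc1cc(-c2nc(-c3ccc4[nH]c(=O)oc4c3)cs2)ccc1F` gives < 20000 nM, again a limit and not a number. Compound 3 `CCc1cc(F)ccc1-c1nc(-c2ccc3[nH]c(=O)oc3c2)cs1` gives < 20000 nM, also a limit of the assay. All three shown values therefore sit at the limit of < 20000 nM in this assay, at which 3 of the 3 values shown sit, so no step between measured compounds can be computed, and on the numbers shown nothing separates compound 3 from the other two. Compound 4 `COCCOCc1cc(F)ccc1-c1nc(-c2ccc3[nH]c(=O)oc3c2)cs1` has not yet been measured in this assay. It differs from compound 3 by 2-methoxyethoxy in place of methyl on a saturated chain carbon bound to an aromatic carbon. Among the measured compounds shown here, with no measured step to lean on, the expected change in this assay is a step that the limit leaves unreadable from compound 3 to compound 4, with no direction beyond the scatter. Compound 4 is accordingly estimated to give 6000 nM in this assay, within a range from 800 nM to 20000 nM.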

Compound 4, half-maximal inhibitory concentration: < 20000 nM
Compound 4: a limit, no number (the forecaster's own chance of this, stated with the estimate: 65%); the middle value is on the limit's open side.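

Among the compounds shown here, compound 4, like compound 3, returns a limit and not a number in this assay, so no step between compound 3 and compound 4 can be read: the limit of < 20000 nM in this assay, at which 4 of the 4 values shown sit. The compounds shown leave open how strongly each one inhibits, and whether 2-methoxyethoxy in place of methyl changes inhibition at all.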